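A few compounds are considered here, and "the series" means these few. Any claim that something is new, unique, unknown or untested is made for them only; others in the source may bear on it.

In a functional assay on IMR-32 cells (Homo sapiens) for cytotoxicity, read by sulforhodamine B assay, with a stated time of 48 h (on this read-out lower numbers stand for stronger inhibition and higher numbers for weaker inhibition), two compounds have values so far:
Compound 1 `COc1ccc(C2CC(c3ccco3)=NN2C(C)=O)cc1` gives 14500 nM
Compound 2 `O=CCN1N=C(c2ccc3ccccc3c2)CC1c1cccc([N+](=O)[O-])c1` gives 3280 nM

Of these two numbers, the value of compound 2 is the lower, and its gap to compound 1 lies beyond the scatter. Compound 3 `O=CCN1N=C(c2ccc3ccccc3c2)CC1c1ccco1` has furan-2-yl in place of 3-nitrophenyl on a saturated ring carbon and has no value in this assay as yet. Among the measured compounds shown here, no measured pair shows this change alone, so the expectation is loose: a modest move toward a higher number, not far beyond the scatter. The step of a 1.8-fold higher number from compound 2 to compound 3 (0.26 log units; within the scatter) is what is expected. For compound 3 the estimated value is 6000 nM with an expected range from 2000 nM to 18000 nM in this test.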

Compound 3, half-maximal inhibitory concentration: 11000 nM
Compound 3: middle estimate off by 1.8-fold (0.26 log units), on the low side; measured number inside the range.
By their numbers in this assay, from the lowest: compound 2; then compounds 3 and 1 (each within the scatter of the next).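

In this assay, the group on the saturated ring carbon next to the ring nitrogen matters: with the rest of the structure unchanged, furan-2-yl in place of 3-nitrophenyl gives a 3.4-fold higher number from compound 2 to compound 3 (0.53 log units; beyond the scatter) in this first single-place comparison. Within these compounds, 3-nitrophenyl is therefore the better of the two groups at this position. No available evidence accounts for this step. The compounds shown leave open whether a plain phenyl or an aminophenyl here would match 3-nitrophenyl. They also leave open whether the nitro group itself or the phenyl ring carries the difference.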